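From 2-Methoxyphenyl to 4-(Trifluoromethyl)phenyl on an Amine Nitrogen

This account rests on a few compounds, and the source may have more. Where it says the series, first, only, none or still open, it means among the compounds named here.

Measured in a functional assay on MGC-803 cells (Homo sapiens) for inhibition, read by sulforhodamine B assay (a lower number here means a stronger inhibitor, a higher number a weaker inhibitor), so far
Compound 1 `O=C1C(Nc2ccc(I)cc2)=CC(=O)c2c1nc1n2[C@H]2OC[C@@H](O)[C@H]2OC1` gives 2150 nM
Compound 2 `O=C1C(NC2CCCC2)=CC(=O)c2c1nc1n2[C@H]2OC[C@@H](O)[C@H]2OC1` gives > 16000 nM (a limit of the assay)
Compound 3 `COc1ccccc1NC1=CC(=O)c2c(nc3n2[C@H]2OC[C@@H](O)[C@H]2OC3)C1=O` gives 1670 nM

On the numbers shown, compound 3 cannot be separated from the only other exact value, with a 1.3-fold lower number from compound 1 to compound 3 (0.11 log units; within the scatter) lying between them. Compound 2 gives only a limit (> 16000 nM).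

Compound 4 `O=C1C(Nc2ccc(C(F)(F)F)cc2)=CC(=O)c2c1nc1n2[C@H]2OC[C@@H](O)[C@H]2OC1` departs from compound 3 in one place (4-(trifluoromethyl)phenyl in place of 2-methoxyphenyl on an amine nitrogen): 4-(trifluoromethyl)phenyl in place of 2-methoxyphenyl on an amine nitrogen. Going by the values given here, the closest precedent is the one measured exchange of one substituted phenyl for another (a 1.3-fold lower number from compound 1 to compound 3 (0.11 log units; within the scatter)), and that exchange stayed within the scatter. The two larger steps (an at least 7.4-fold higher number from compound 1 to compound 2 (0.87 log units; beyond the scatter) and an at least 9.5-fold lower number from compound 2 to compound 3 (0.98 log units; beyond the scatter)) both involve cyclopentyl, which plays no part here, since compound 4 keeps a six-membered aromatic ring on that nitrogen. In this assay, as far as these compounds go, no step beyond the scatter is therefore expected, and the direction stays open. The expected move is small (a 1.2-fold higher number from compound 3 to compound 4 (0.08 log units; within the scatter)). Compound 4 is estimated at about 2000 nM (expected range 800 nM to 5500 nM).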

Compound 4, half-maximal inhibitory concentration: 1860 nM
For compound 4 the middle estimate is 1.1-fold (0.03 log units) above the measured one, and the stated range covers the measured number.
By their numbers in this assay, from the lowest: compounds 3, 4 and 1 (each within the scatter of the next). At a limit, above all of these: compound 2.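

In this assay, 4-(trifluoromethyl)phenyl on the amine nitrogen cannot be told apart from either of the other two substituted phenyl groups, with a 1.1-fold higher number from compound 3 to compound 4 (0.05 log units; within the scatter) and with a 1.2-fold lower number from compound 1 to compound 4 (0.06 log units; within the scatter) for trifluoromethyl in place of iodo on an aromatic carbon. Compounds 1, 3 and 4 thus form a group of three whose numbers lie within the scatter of one another, although the substituent on the phenyl ring differs in each and none of the three goes against this. Cyclopentyl remains apart from this group, now also against compound 4, with an at least 8.6-fold lower number from compound 2 to compound 4 (0.93 log units; beyond the scatter), and that step has no upper end because compound 2 gives a limit: the limit of > 16000 nM in this assay, at which 1 of the 4 values shown sits.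

How far this tolerance extends remains open, since the compounds shown do not say whether an unsubstituted phenyl ring, a pyridine ring or a benzyl group on the nitrogen would fall within the same group. Nor do they show whether a phenyl ring bearing a carboxylic acid or an amine would stay there, or whether a longer alkyl chain would behave like cyclopentyl.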